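Swapping the ester linker for an amide in a small series

The source may hold more compounds than are shown below. What is called first, only, known or untested is meant among the compounds shown, and "the series" means these compounds.

- Compound 1 `C/C=C(\C)C(=O)O[C@H]1C=CC(=O)O[C@H]1CCC(=O)[C@H](C)O` gives 18000 nM
- Compound 2 `C/C=C(\C)C(=O)O[C@H]1C=CC(=O)O[C@H]1COC(=O)[C@H](C)O` gives 11000 nM

Both values come from a functional assay on COLO 205 cells (Homo sapiens) for antiproliferative activity, read by sulforhodamine B assay, with a stated time of 48 h; a higher number here means a weaker inhibitor, a lower number a stronger inhibitor. Within the data shown here, compound 2 has the lower of the two numbers, but it cannot be separated from compound 1, the only other measured compound: the gap is a 1.6-fold lower number from compound 1 to compound 2 (0.21 log units; within the scatter).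

Compound 3 `C/C=C(\C)C(=O)O[C@H]1C=CC(=O)O[C@H]1CNC(=O)[C@H](C)O` differs from compound 2 by one change: ((1-hydroxyethyl)carbonyl)amino in place of ((1-hydroxyethyl)carbonyl)oxy on a saturated chain carbon bound to a saturated ring carbon. Among the measured compounds shown here, one measured step bears on this, since it also exchanges the group at this place, and it stayed within the scatter. For the measured compounds named here, no measured compound carries the ((1-hydroxyethyl)carbonyl)amino group, so the data give no direct reading of it. No step beyond the scatter is therefore expected in this assay, although the range is kept wide. The expected change is a 1.3-fold higher number from compound 2 to compound 3 (0.10 log units; within the scatter). For compound 3 the estimated value is 14000 nM, with an expected range of 6000 nM to 32000 nM.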

Compound 3, half-maximal inhibitory concentration: 25000 nM
Compound 3: middle estimate off by 1.8-fold (0.25 log units), on the low side; the measured number falls inside the stated range.
By their numbers in this assay, from the lowest: compounds 2, 1 and 3 (each within the scatter of the next, the first and the last beyond it).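

In this assay, among these compounds, the saturated chain carbon bound to a saturated ring carbon now shows a change that can be read: ((1-hydroxyethyl)carbonyl)amino in place of ((1-hydroxyethyl)carbonyl)oxy gives a 2.3-fold higher number from compound 2 to compound 3 (0.36 log units; beyond the scatter) and is the first step here beyond the scatter. The same group in place of ((1-hydroxyethyl)carbonyl)methyl gives a 1.4-fold higher number from compound 1 to compound 3 (0.14 log units; within the scatter) and stays within the scatter, so compound 1 cannot be separated from either of the other two and only the exchange of oxy for amino registers, modestly. No evidence is available that would explain this step.

Going by these compounds, it remains open whether an amine or a carboxylic acid at this place, or a longer chain in the ((1-hydroxyethyl)carbonyl)amino group, would move the number further. On these data alone, it also remains open whether the step from oxy to amino would hold on a different core.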